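A few compounds are considered here, and "the series" means these few. Any claim that something is new, unique, unknown or untested is made for them only; others in the source may bear on it.

Compound 1 `O=C1N=C(C2C(=O)c3ccccc3C2=O)CC(c2cccc([N+](=O)[O-])c2)N1` gives 36% in a functional assay on the whole organism for inhibition, with Mus musculus as the target, in the writhing test, with a stated time of 15 min, at a dose of 10 mg/kg; a higher number here means more inhibition at the dose given (going by the name of the read-out), a lower number less inhibition. Compound 2 `O=C1N=C(C2C(=O)c3ccccc3C2=O)CC(c2ccc([N+](=O)[O-])cc2)N1` gives 38% in this assay. Compound 3 `O=C1N=C(C2C(=O)c3ccccc3C2=O)CC(/C=C/c2ccccc2)N1` gives 16% in this assay.

Among these three, compound 3 stands lowest: a number 20 percentage points lower from compound 1 to compound 3 (beyond the scatter) and a number 22 percentage points lower from compound 2 to compound 3 (beyond the scatter), while compounds 1 and 2 lie close together, since a number 2 percentage points higher from compound 1 to compound 2 (within the scatter). The shared core is kept in every case, and only the group on the saturated ring carbon changes.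

Compound 4 `O=C1N=C(C2C(=O)c3ccccc3C2=O)CC(c2ccco2)N1` differs from compound 3 in one place: furan-2-yl in place of 2-phenylethenyl on a saturated ring carbon. Within the data shown here, no measured step involves furan-2-yl, so there is no direct guide. The two steps that bear on the change are those in which 2-phenylethenyl replaced a nitrophenyl group, each a modest drop. Putting a small aromatic ring back in place of 2-phenylethenyl is therefore expected to recover part of that loss, though how much stays uncertain. Compound 4 is expected to give 28% in this assay, with a likely range from 10% to 46%. The expected step is a number 12 percentage points higher from compound 3 to compound 4 (beyond the scatter).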

Compound 4, a percentage reported as inhibition, in the whole organism at one dose (the size of the read-out at that dose, not a potency): 25%
The estimate for compound 4 lay 3 percentage points above the measured number; low and high end bracket the measured number.
By their numbers in this assay, from the lowest: compounds 3 and 4 (each within the scatter of the next); then compounds 1 and 2 (each within the scatter of the next).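

In this assay the step of a number 9 percentage points higher from compound 3 to compound 4 (within the scatter) means that furan-2-yl and 2-phenylethenyl cannot be told apart on this saturated ring carbon, although they differ in ring size and in the double bond outside the ring. The steps of a number 11 percentage points lower from compound 1 to compound 4 (beyond the scatter) and a number 13 percentage points lower from compound 2 to compound 4 (beyond the scatter) set furan-2-yl clearly short of both nitrophenyl groups, so among these four compounds an aromatic ring on this carbon does not by itself give the higher numbers. Nothing measured here explains that gap.

The compounds shown leave open whether the higher numbers go with the nitro group or with the six-membered aromatic ring that carries it. A plain phenyl ring on this carbon, or a phenyl ring bearing an amine in place of the nitro group, would help to separate the two.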